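Extending the Acid Arm of Compound 2

The compounds below may be only part of what the source reports. "The series", "measured", "known", "first", "only" and "open" are said of these compounds alone.

Compound 1 `Cc1nc(-c2ccc(C(F)(F)F)cc2)sc1CNc1ccc(CCC(=O)O)cc1` reaches 108% in a functional assay on CHO cells for agonist activity at Free fatty acid receptor 1 (Homo sapiens), read by a luciferase reporter; a lower number here means a smaller maximal response, a higher number a larger maximal response. Its relative compound 3 `Cc1nc(-c2ccc(C(F)(F)F)cc2)sc1CNc1ccc(OCC(=O)O)cc1` gives 100% in this assay, and the step of a number 8 percentage points lower from compound 1 to compound 3 (within the scatter) shows that swapping one acid-bearing arm for another of different length and linkage left the maximal response essentially unchanged. Compound 2 `O=C(O)c1ccc(NCc2cccc(Oc3ccccc3)c2)cc1`, built on a different core, gives 86% in this assay; this is the lowest of the three values, with compound 3 and compound 1 both standing beyond the scatter above it. Compound 4 `O=C(O)CSc1ccc(NCc2cccc(Oc3ccccc3)c2)cc1` keeps the core of compound 2 and differs only by (carboxymethyl)sulfanyl in place of carboxy on an aromatic carbon. Going by the values given here, the one measured step that bears on such a change in the acid arm, from compound 1 to compound 3, was within the scatter, so a step of similar size is expected here, in no particular direction. Compound 4 is therefore expected to show a shift of a number 2 percentage points higher from compound 2 to compound 4 (within the scatter), landing at an estimated 88% in this assay, within a range of 68% to 108%.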

Compound 4, largest response reached (reported as percent of maximum), in percent of the reference or control that the assay uses: 84%
Compound 4: the middle estimate sits 4 percentage points above what was measured; the range from low to high includes it.
By their numbers in this assay, from the lowest: compounds 4 and 2 (each within the scatter of the next); then compounds 3 and 1 (each within the scatter of the next).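

On the core of compound 2, replacing carboxy with (carboxymethyl)sulfanyl on the aromatic carbon para to a large group gives a number 2 percentage points lower from compound 2 to compound 4 (within the scatter) in this assay, so the maximal response does not distinguish the two arms. The earlier step, a number 8 percentage points lower from compound 1 to compound 3 (within the scatter), compared two arms on a different core, whereas this one shows that an arm of 5 heavy atoms containing sulfur can take the place of the 3-atom carboxy group at this position with the two values staying within the scatter of each other. No measurement bearing on why these two values stay so close is at hand. As far as these compounds go, what remains open is whether a longer chain ending in the carboxylic acid would also keep the response on this core. From the compounds shown here alone, it is equally open whether an amine or a tetrazole at the end of the arm would do so.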